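This account rests on a few compounds, and the source may have more. Where it says the series, first, only, none or still open, it means among the compounds named here.

Of the compounds shown here, three have so far been measured in a functional assay on K562 cells (Homo sapiens), read by MTT assay, with a stated time of 72 h; a higher number here means a weaker inhibitor, a lower number a stronger inhibitor.

Compound 1 `C#Cc1cn([C@@H]2O[C@H](CO)[C@@H](O)[C@H]2O)c2ncnc(OC)c12` gives 380 nM.
Compound 2 `COc1ncnc2c1c(-c1ccccc1)cn2[C@@H]1O[C@H](CO)[C@@H](O)[C@H]1O` gives only a limit of the assay, > 20000 nM.
Compound 3 `CNc1ncnc2c1c(-c1ccsc1)cn2[C@@H]1O[C@H](CO)[C@@H](O)[C@H]1O` likewise gives only a limit, > 20000 nM.

Compound 3 thus stands at the edge of what this assay can report: a limit rather than a number, shared with compound 2 as shown by the limit of > 20000 nM in this assay, at which 2 of the 3 values shown sit. Among these three, only compound 1 gives a true number.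

Compound 4 `COc1ncnc2c1c(-c1ccsc1)cn2[C@@H]1O[C@H](CO)[C@@H](O)[C@H]1O` differs from compound 3 in one place: methoxy in place of methylamino on an aromatic carbon. Among the measured compounds shown here, the single measured step, an at least 52-fold higher number from compound 1 to compound 2 (1.72 log units; beyond the scatter), concerns a different part of the structure and does not bear directly on this change. What can be said is that compound 2 already carries the same methoxy group as compound 4, and its result in this assay is a limit. Both compounds with an aromatic ring on the core, compound 2 and compound 3, sit at the limit, so the methoxy for methylamino exchange is not expected to lift compound 4 into the measurable range.

Compound 4 is therefore estimated at about 20000 nM, with a range from 6000 nM to 60000 nM, most likely reported again as a limit. The step this estimate implies, a number no higher from compound 3 to compound 4 (the limit leaves the size open), is expected to be no change beyond the scatter.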

Compound 4, half-maximal inhibitory concentration: 3450 nM
Compound 4: middle estimate off by 5.8-fold (0.76 log units), on the high side; the whole stated range lies above it.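

In this assay, changing one group at a time shows that two places on the shared core both matter: methoxy in place of methylamino, on the aromatic carbon next to the ring nitrogen, gives an at least 5.7-fold lower number from compound 3 to compound 4 (0.76 log units; beyond the scatter), and thiophen-3-yl in place of phenyl gives an at least 5.7-fold lower number from compound 2 to compound 4 (0.76 log units; beyond the scatter). An aromatic ring on the core is therefore not always enough to push a compound out of the measurable range, although thiophen-3-yl in place of ethynyl still gives a 9.1-fold higher number from compound 1 to compound 4 (0.96 log units; beyond the scatter). The two steps that lead to compound 4 from compounds 2 and 3 give only a smallest possible size, because their starting compounds are reported as a limit and not as a number: the limit of > 20000 nM in this assay, at which 2 of the 4 values shown sit.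

The compounds shown leave open how a plain amino group or an ethoxy group would compare with methoxy on that aromatic carbon, and how a furan-3-yl ring would compare with thiophen-3-yl. As far as these compounds go, it also remains open whether the exchange of methylamino for methoxy would have a similar effect with ethynyl on the core.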